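Replacing 5-methoxypyridin-3-yl with 1,3-benzothiazol-5-yl

A few compounds are considered here, and "the series" means these few. Any claim that something is new, unique, unknown or untested is made for them only; others in the source may bear on it.

In an ADME assay (liver) for metabolic stability, with Liver microsome (Rattus norvegicus) as the target, using microsomes and NADPH, with a stated time of 30 min, tested at 1 uM (on this read-out lower numbers stand for slow clearance and higher numbers for fast clearance), compound 2 (`COc1cncc(-c2cc(C(O)(C(F)(F)F)C(F)(F)F)cnc2N2CCN(S(=O)(=O)c3ccc(N)nc3)CC2)c1`) gives 58 mL.min-1.g-1 and compound 1 (`CS(=O)(=O)c1ccc(-c2cc(C(O)(C(F)(F)F)C(F)(F)F)cnc2N2CCN(S(=O)(=O)c3ccc(N)nc3)CC2)cc1`) gives 103 mL.min-1.g-1 on the same scale, so these two numbers lie within the scatter of each other. Compound 3 (`Nc1ccc(S(=O)(=O)N2CCN(c3ncc(C(O)(C(F)(F)F)C(F)(F)F)cc3-c3ccc4scnc4c3)CC2)cn1`) differs from compound 2 at one place (1,3-benzothiazol-5-yl in place of 5-methoxypyridin-3-yl on an aromatic carbon) with 1,3-benzothiazol-5-yl in place of 5-methoxypyridin-3-yl. Within the data shown here, the only measured step at that place (a 1.8-fold lower number from compound 1 to compound 2 (0.25 log units; within the scatter)) stays within the scatter, so no step beyond the scatter is expected in this assay here. The expected step (a 1.4-fold higher number from compound 2 to compound 3 (0.14 log units; within the scatter)) is upward but small. For compound 3 the estimate is 80 mL.min-1.g-1 with an expected range from 35 mL.min-1.g-1 to 180 mL.min-1.g-1 for repeat measurements.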

Compound 3, intrinsic clearance in microsomes: 147 mL.min-1.g-1
For compound 3 the middle estimate is 1.8-fold (0.26 log units) below the measured one, and the stated range covers the measured number.
By their numbers in this assay, from the lowest: compounds 2, 1 and 3 (each within the scatter of the next, the first and the last beyond it).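

Among these compounds, with 1,3-benzothiazol-5-yl in place of 5-methoxypyridin-3-yl, this assay shows a 2.5-fold higher number from compound 2 to compound 3 (0.40 log units; beyond the scatter) and so gives the only step beyond the scatter at this position. In place of 4-(methylsulfonyl)phenyl, the same group gives a 1.4-fold higher number from compound 1 to compound 3 (0.15 log units; within the scatter) and so stands apart only from 5-methoxypyridin-3-yl. No measurement here accounts for that step. Still open, as far as these compounds go, is how a plain phenyl or a saturated ring amine such as morpholine would compare at this position. Also open, from the compounds shown here alone, is whether a methoxy group on a benzothiazole would give a number closer to that of compound 2.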